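This account rests on a few compounds, and the source may have more. Where it says the series, first, only, none or still open, it means among the compounds named here.

Measured so far: compound 1 `CN(C)c1c(C#N)c2c(N)ncnc2n1C` gives 3760 nM; compound 2 `C[C@@H]1CCCN1c1c(C#N)c2c(N)ncnc2n1C` gives 11 nM; compound 3 `Cn1c(-c2ccccc2)c(C#N)c2c(N)ncnc21` gives 483 nM.

In an assay on isolated protein for inhibition of Leucine-rich repeat serine/threonine-protein kinase 2 variant G2019S (Homo sapiens), read by TR-FRET and LanthaScreen, with stated times of 50 min and 30 min, in the presence of a further agent that is not named here (a lower number here means a stronger inhibitor, a higher number a weaker inhibitor), compound 3 stands second highest of the three numbers: there is a 7.8-fold lower number from compound 1 to compound 3 (0.89 log units; beyond the scatter) and a 44-fold higher number from compound 2 to compound 3 (1.64 log units; beyond the scatter). Compound 4 `C[C@H]1CCCN1c1c(C#N)c2c(N)ncnc2n1C` arises from compound 3 by 2-methylpyrrolidin-1-yl in place of phenyl on an aromatic carbon; it differs from compound 2 only in the configuration of that single stereocentre. The step that bears on this change is the reverse of a 44-fold higher number from compound 2 to compound 3 (1.64 log units; beyond the scatter), a large one. A large drop is therefore expected, tempered by the untested stereocentre, with a 9.7-fold lower number from compound 3 to compound 4 (0.98 log units; beyond the scatter) as the expected step. Compound 4 is estimated at 50 nM, within 8 nM to 300 nM.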

Compound 4, half-maximal inhibitory concentration: 3080 nM
The estimate for compound 4 lay 62-fold (1.79 log units) below the measured number; measured number above the stated range.
By their numbers in this assay, from the lowest: compound 2; then compound 3; then compounds 4 and 1 (each within the scatter of the next).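

In this assay, the 2-methylpyrrolidin-1-yl group on this aromatic carbon gives strong inhibition only with the right configuration, and the stereocentre alone accounts for a 280-fold higher number from compound 2 to compound 4 (2.45 log units; beyond the scatter): the fact that compounds 2 and 4 differ only in the configuration as drawn With the S configuration, replacing phenyl brings no gain, giving a 6.4-fold higher number from compound 3 to compound 4 (0.80 log units; beyond the scatter). Against dimethylamino, the S form shows a 1.2-fold lower number from compound 1 to compound 4 (0.09 log units; within the scatter), so only the R form stands apart from that small amine.

On these data alone, whether the methyl group is needed at all, as against a plain pyrrolidin-1-yl, remains open. So does whether an ethyl group on that ring carbon would keep the preference for the R configuration.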